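The source may report more compounds than this note shows. Statements on the series, on what has been measured and on what is new or still open speak of the compounds shown alone.

In a functional assay (aorta) with Rattus norvegicus as the target (a higher number here means that more compound is needed for the effect, a lower number that less compound is needed), three compounds sharing one core have been measured. Compound 1 `COc1ccc(-c2nc(/N=C(\N)N(C)C)sc2-c2ccc(OC)cc2)cc1` gives 4.8 uM. Compound 2 `CCOC(=O)/C=C/c1nc(-c2ccc(OC)cc2)c(-c2ccc(OC)cc2)s1` gives > 100 uM, which is a limit of the assay and not a number. Compound 3 `COc1ccc(-c2nc(/C=C/C(=O)O)sc2-c2ccc(OC)cc2)cc1` gives 55 uM, the higher of the two actual numbers in this assay. The nearest of those numbers is reached through an 11-fold higher number from compound 1 to compound 3 (1.06 log units; beyond the scatter).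

Compound 4 `COc1ccc(-c2nc(/C=C/C(=O)N3CCN(C)CC3)sc2-c2ccc(OC)cc2)cc1` has not yet been measured. It departs from compound 3 through (4-methylpiperazin-1-yl in place of hydroxy on a carbonyl carbon), which puts 4-methylpiperazin-1-yl in place of hydroxy on a carbonyl carbon.

The closest measured step also concerns the carboxy group, and it is an at least 1.8-fold lower number from compound 2 to compound 3 (0.25 log units; that floor lies within the scatter). Its floor lies within the scatter, so it offers no firm sign of a large effect from changing this group. The two large steps, an at least 20-fold higher number from compound 1 to compound 2 (1.31 log units; beyond the scatter) and an 11-fold higher number from compound 1 to compound 3 (1.06 log units; beyond the scatter), exchange the entire group on the aromatic carbon, so they bear less directly on a change confined to the carbonyl carbon. They do, however, justify keeping a wide range. No step beyond the scatter is therefore expected in this assay. The estimated step is a 1.4-fold lower number from compound 3 to compound 4 (0.14 log units; within the scatter). Compound 4 is expected at 40 uM, with an estimated range of 10 uM to 100 uM.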

Compound 4, concentration for half-maximal effect: 20 uM
Estimate against measurement, compound 4: 2.0-fold (0.30 log units) above, and the stated range covers the measured number.
By their numbers in this assay, from the lowest: compound 1; then compound 4; then compound 3. At a limit, above all of these: compound 2.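

In this assay, the earlier step on this carbonyl carbon, from the ethyl ester to the acid, had a floor within the scatter and so gave no firm sign that a change here matters; the new result gives that sign, with a 2.8-fold lower number from compound 3 to compound 4 (0.44 log units; beyond the scatter). The value of compound 2 is a limit of the assay and not a number: the limit of > 100 uM in this assay, at which 1 of the 4 values shown sits. Measured against that limit, exchanging ethoxy for 4-methylpiperazin-1-yl on the same carbonyl carbon gives an at least 5.0-fold lower number from compound 2 to compound 4 (0.69 log units; beyond the scatter), so the amide stands apart from both the acid and the ester, although the size of the second step is only a floor.

What the compounds shown leave open is whether the 4-methylpiperazin-1-yl ring itself carries this modest step, or whether a morpholin-4-yl group, a piperazin-1-yl group without the methyl or a simple dimethylamino group on the carbonyl carbon would do the same. They also leave open whether the step would hold with a saturated chain in place of the double-bonded chain carbon that carries the carbonyl group.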